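The compounds below may be only part of what the source reports. "The series", "measured", "known", "first", "only" and "open" are said of these compounds alone.

Among the measured compounds shown here, compound 2, whose structure is `Cc1ccnc(/C(N)=N/NC(=S)N2CCCC2)c1`, shows the lowest number among the three compounds measured so far in a functional assay on HeLa cells (Homo sapiens) for cytotoxicity, read by MTT assay, with a stated time of 72 h; on this read-out higher numbers stand for weaker inhibition and lower numbers for stronger inhibition. In this assay compound 2 gives 1900 nM. Its nearest neighbour is compound 3, built as `N/C(=N\NC(=S)N1CCOCC1)c1ccccn1`, for which this assay gives 7300 nM. The furthest is compound 1, built as `Cc1ccnc(/C(N)=N/NC(=S)N2CCSCC2)c1`, with a value in this assay of 15500 nM. For the measured compounds named here, the one step that links two compounds differing in a single place is an 8.2-fold lower number from compound 1 to compound 2 (0.91 log units; beyond the scatter).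

Compound 4, drawn as `Cc1ccnc(/C(N)=N/NC(=S)N2CCCCC2)c1`, has not yet been measured in this assay. Its difference from compound 2 is piperidin-1-yl in place of pyrrolidin-1-yl on a thiocarbonyl carbon. Going by the values given here, no measured step exchanges a five-membered for a six-membered non-aromatic ring at this position, so the only guide is indirect: the step from compound 1 to compound 2 replaced a six-membered ring by pyrrolidin-1-yl and gave a clearly lower number, and compound 3, which also carries a six-membered ring at the thiocarbonyl carbon, sits higher than compound 2. On that basis a moderately higher number is expected for compound 4, though a step within the scatter cannot be ruled out. The estimated step is a 1.8-fold higher number from compound 2 to compound 4 (0.27 log units; within the scatter), and compound 4 is expected to give 3500 nM in this assay, within a range from 1200 nM to 10000 nM.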

Compound 4, half-maximal inhibitory concentration: 7700 nM
Estimate against measurement, compound 4: 2.2-fold (0.34 log units) below; low and high end bracket the measured number.
By their numbers in this assay, from the lowest: compound 2; then compounds 3, 4 and 1 (each within the scatter of the next, the first and the last beyond it).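

Among the compounds shown here, the exchange of pyrrolidin-1-yl for piperidin-1-yl in this assay gives a 4.1-fold higher number from compound 2 to compound 4 (0.61 log units; beyond the scatter), the first direct comparison of a five-membered with a six-membered non-aromatic ring on the thiocarbonyl carbon. The exchange of thiomorpholin-4-yl for piperidin-1-yl gives a 2.0-fold lower number from compound 1 to compound 4 (0.30 log units; within the scatter), so these two six-membered rings are not separated by this read-out, whether or not the ring carries sulfur. Among compound 1, compound 2 and compound 4, which differ only at this position, the clearly lower number therefore belongs to the pyrrolidin-1-yl ring of compound 2 alone, and neither six-membered ring goes against this.

No evidence is available that accounts for this gap between the ring sizes. On these data alone, it remains open whether azetidin-1-yl, azepan-1-yl or an open-chain diethylamino group on the thiocarbonyl carbon would give a number closer to that of compound 2 or to that of compound 4, and whether a methyl or hydroxyl group on the pyrrolidin-1-yl ring itself would keep the number of compound 2.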